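The compounds below may be only part of what the source reports. "The series", "measured", "known", "first", "only" and "open" are said of these compounds alone.

In an assay on HEK293 cells for displacement of a labelled ligand from NPC1-like intracellular cholesterol transporter 1 (Homo sapiens) (on this read-out higher numbers stand for weaker inhibition and lower numbers for stronger inhibition), compound 1, whose structure is `CC(C)(C)OC(=O)NCCNC(=O)CN1CN(c2ccccc2)C2(CCN(C(=O)c3ccc(C(C)(C)C)cc3)CC2)C1=O`, gives 10900 nM. This is the highest of the three numbers in hand. Compound 2, `O=C(CN1CN(c2ccccc2)C2(CCN(C(=O)c3ccc(C4CCCCC4)cc3)CC2)C1=O)NCCO`, gives 2000 nM in this assay, and compound 3, `O=C(CN1CN(c2ccccc2)C2(CCN(C(=O)c3ccc(C4CCCCC4)cc3)CC2)C1=O)N1CCC(CO)CC1`, gives 1100 nM. Among the compounds with values here, the only measured step, a 1.8-fold lower number from compound 2 to compound 3 (0.26 log units; within the scatter), lies within the scatter; both of those compounds carry a cyclohexyl on the benzoyl ring that compound 1 does not, so neither of them shares the tert-butyl side of compound 1, and no measured step touches the place altered here.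

Compound 4, `CC(C)(C)c1ccc(C(=O)N2CCC3(CC2)C(=O)N(CC(=O)NCN)CN3c2ccccc2)cc1`, differs from compound 1 by amino in place of ((tert-butoxycarbonyl)amino)methyl on a saturated chain carbon bound to an amide-type nitrogen. The chain on the amide is thus cut back sharply. Within the data shown here, since no measured pair tests this change, the expectation can rest only on the general picture: compounds 2 and 3, with short polar groups on the amide, sit at lower numbers than compound 1 in this assay, but they differ from compound 1 in two places, so the comparison is loose. The author therefore expects a modest move to a lower number, a 1.8-fold lower number from compound 1 to compound 4 (0.26 log units; within the scatter), with wide uncertainty. For compound 4 the estimate in this assay is 6000 nM, within a range from 1500 nM to 25000 nM.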

Compound 4, half-maximal inhibitory concentration: 26500 nM
Compound 4: the middle estimate sits 4.4-fold (0.65 log units) below what was measured; the measured number lies above the stated range.
By their numbers in this assay, from the lowest: compounds 3 and 2 (each within the scatter of the next); then compound 1; then compound 4.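

In this assay, within the data shown here, the one step at this position reads a 2.4-fold higher number from compound 1 to compound 4 (0.39 log units; beyond the scatter), which is the first measured change on a saturated chain carbon bound to an amide-type nitrogen. It shows that replacing ((tert-butoxycarbonyl)amino)methyl, with its 9 heavy atoms, by amino, with its 1 heavy atom, moves the number up, modestly but beyond the scatter, so on the tert-butyl side of the series the shorter end does not bring a gain on this read-out. Nothing at hand gives a reason for this step.

The compounds shown leave open how the number would respond to something intermediate at this place, such as an aminoethyl chain, or to a different end group, such as a carboxylic acid or a hydroxyl. Also open, as far as these compounds go, is whether the same change would move the number in the same direction in compounds that carry cyclohexyl on the benzoyl ring, as compound 2 and compound 3 do, rather than the tert-butyl of compound 1 and compound 4.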